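The compounds below may be only part of what the source reports. "The series", "measured", "known", "first", "only" and "open" are said of these compounds alone.

Working notes on the series, read in an in vitro ADME assay on microsomes from liver (Homo sapiens) for pharmacokinetics, read by LC-MS, with a stated time of 10 min, tested at 1 uM; a higher number here means faster removal of the compound, a lower number slower removal. Compound 1 (`CCN1C[C@H](C(=O)Nc2ccc(Cl)cc2)[C@@H](c2ccc(/C=C/C(=O)Nc3ccccc3N)cc2)C1`) gives 12 mL/min/kg and compound 2 (`N#CCN1C[C@H](C(=O)Nc2ccc(Cl)cc2)[C@@H](c2ccc(/C=C/C(=O)Nc3ccccc3N)cc2)C1`) gives 17 mL/min/kg. These two values lie within the scatter of each other, so compound 2 cannot be separated from compound 1 on the numbers available.

The next structure is compound 3 (`CCN(CC)C(=O)N1C[C@H](C(=O)Nc2ccc(Cl)cc2)[C@@H](c2ccc(/C=C/C(=O)Nc3ccccc3N)cc2)C1`), which carries diethylcarbamoyl in place of cyanomethyl on an amine nitrogen in a ring. Within the data shown here, the only measured step that bears on this change is the one at the group on the same amine nitrogen, a 1.4-fold higher number from compound 1 to compound 2 (0.15 log units; within the scatter). Among the measured compounds shown here, it is a single step and it involves a different exchange, and no measured compound carries diethylcarbamoyl, so it offers only weak guidance. Since that step stays within the scatter, no step beyond the scatter is expected in this assay, and no direction is favoured with any confidence. The estimated step is a 1.2-fold higher number from compound 2 to compound 3 (0.07 log units; within the scatter). For compound 3 the estimated value is 20 mL/min/kg, with an expected range of 9 mL/min/kg to 42 mL/min/kg.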

Compound 3, clearance: 19 mL/min/kg
Compound 3: middle estimate off by 1.1-fold (0.02 log units), on the high side; the range from low to high includes it.
By their numbers in this assay, from the lowest: compounds 1, 2 and 3 (each within the scatter of the next).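

On the amine nitrogen in the five-membered ring, diethylcarbamoyl in place of cyanomethyl gives a 1.1-fold higher number from compound 2 to compound 3 (0.05 log units; within the scatter) in this assay, and diethylcarbamoyl in place of ethyl gives a 1.6-fold higher number from compound 1 to compound 3 (0.20 log units; within the scatter) in the same read-out. The earlier pair held only ethyl and cyanomethyl at this position, whereas the exchange now reaches a group of 7 heavy atoms in place of one of 3, with a double bond outside aromatic rings in place of a triple bond, and all three compounds remain within the scatter of one another on these steps. No supporting data accompany these numbers to explain why the values stay so close, so the result stands as a description only.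

The compounds shown leave open whether any group on this nitrogen separates from these three values, for example a carboxylic acid on a longer chain, a primary amine or a plain hydrogen. They also leave open whether the same tolerance holds when the (4-chlorophenyl)carbamoyl group on the ring is exchanged, for example for a pyridyl amide.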